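The compounds below may be only part of what the source reports. "The series", "measured", "known", "first", "only" and "open" are said of these compounds alone.

Measured so far in a functional assay on the whole organism (strain Wistar) for inhibition, with Rattus norvegicus as the target, read by paw edema, with stated times of 30 min and 5 h, at a dose of 0.05 mmol/kg by the oral route; a higher number here means more inhibition at the dose given (going by the name of the read-out), a lower number less inhibition:
- compound 1, `COc1ccc(C2=NN(c3ccc(S(C)(=O)=O)cc3)C(=O)CC2)cc1`, gives 68.4%.
- compound 2, `Cc1cc(C2=NN(c3ccc(S(C)(=O)=O)cc3)C(=O)CC2)ccc1O`, gives 60.5%.

Within the data shown here, compound 2 stands lowest of the two numbers; its nearest neighbour is compound 1, and the one step between them, a number 7.9 percentage points lower from compound 1 to compound 2 (within the scatter), lies within the scatter, so the two cannot be ordered on these data.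

Compound 3, `Cc1cc(O)ccc1C1=NN(c2ccc(S(C)(=O)=O)cc2)C(=O)CC1`, is the next candidate. It differs from compound 2 in one place: 4-hydroxy-2-methylphenyl in place of 4-hydroxy-3-methylphenyl on a carbon with a double bond to nitrogen. The methyl thus moves from one side of the hydroxyphenyl ring to the other, with the same atoms joined differently.

Among the measured compounds shown here, no measured step moves a methyl around this ring. For the measured compounds named here, the only step in hand, from compound 1 to compound 2, swaps the whole aryl group and is within the scatter, so it bears on compound 3 only in showing that a change at this carbon left this assay roughly where it was. On that basis the expected step is a number 2.5 percentage points lower from compound 2 to compound 3 (within the scatter), that is, none beyond the scatter, in no particular direction.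

For compound 3 the estimate in this assay is 58%, expected to fall between 44% and 71%.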

Compound 3, a percentage reported as inhibition, in the whole organism at one dose (the size of the read-out at that dose, not a potency): 52.6%
Estimate against measurement, compound 3: 5.4 percentage points above; low and high end bracket the measured number.
By their numbers in this assay, from the lowest: compounds 3, 2 and 1 (each within the scatter of the next, the first and the last beyond it).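

In this assay, moving the methyl around the ring, with 4-hydroxy-2-methylphenyl in place of 4-hydroxy-3-methylphenyl, gives a number 7.9 percentage points lower from compound 2 to compound 3 (within the scatter), so this pair cannot be ordered and the placing of the methyl has no readable effect at this dose. The aryl group on the carbon with a double bond to nitrogen does now show a step that can be read: 4-hydroxy-2-methylphenyl in place of 4-methoxyphenyl gives a number 15.8 percentage points lower from compound 1 to compound 3 (beyond the scatter), a modest step and the first in the series beyond the scatter, while compound 2 stays within the scatter of both compound 1 and compound 3. No measurement on these compounds accounts for either step.

Going by these compounds, compound 3 differs from compound 1 in both the hydroxy group and the methyl at once, so it remains open which of the two carries the modest step. On these data alone, it is also open how the series responds at this position to an aryl group bearing an amine or a carboxylic acid in place of the hydroxy group.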